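A few compounds are considered here, and "the series" means these few. Any claim that something is new, unique, unknown or untested is made for them only; others in the source may bear on it.

Working notes on the series. In a functional assay on PC-3 cells (Homo sapiens) for cytotoxicity, read by MTT assay, with a stated time of 72 h (a lower number here means a stronger inhibitor, a higher number a weaker inhibitor), compound 1 `COc1ccc(-c2cc(C(=O)Nc3ccc(Oc4ccnc5[nH]ccc45)cc3)ncn2)cc1` gives 9830 nM. Compound 2 `O=C(Nc1ccc(Oc2ccnc3[nH]ccc23)cc1)c1cc(-c2ccc(F)cc2)ncn1` is reported in this assay as "not active" (no number reported), with no number behind it, so on the numbers shown compound 2 stands only as inactive and no step from compound 1 to compound 2 can be sized. Compound 3 `O=C(Nc1ccc(Oc2ccnc3[nH]ccc23)cc1)c1cc(-c2ccc(Cl)cc2)ncn1` differs from compound 2 by chloro in place of fluoro on an aromatic carbon. For the measured compounds named here, no step between measured compounds fixes a direction here; the expectation is a step of no more than the scatter, with a fair chance that this assay again returns no number. Compound 3 is expected at about 25000 nM, within 6000 nM to 100000 nM.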

Compound 3, half-maximal inhibitory concentration: 15600 nM
Compound 3: middle estimate off by 1.6-fold (0.20 log units), on the high side, and the stated range covers the measured number.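

In this assay, chloro at this position gives a number where fluoro gave none: compound 2 stands only as inactive, while compound 3 gives 15600 nM in the same assay. Chloro and methoxy on this aromatic carbon are not told apart, with a 1.6-fold higher number from compound 1 to compound 3 (0.20 log units; within the scatter) on the shared core. Nothing available accounts for the fluoro compound's lack of a number.

Any step to or from compound 2 cannot be read. As far as these compounds go, whether an amine, a carboxylic acid or a longer chain such as ethoxy at this position would keep a number in this assay remains open.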